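The source may report more compounds than this note shows. Statements on the series, on what has been measured and on what is new or still open speak of the compounds shown alone.

Three compounds sharing one core were tested in a functional assay on BXPC-3 cells (Homo sapiens) for antiproliferative activity, read by MTT assay, with a stated time of 24 h; a higher number here means a weaker inhibitor, a lower number a stronger inhibitor. Compound 1 (`CCn1c(C(=O)N[C@@H](C)C(=O)OC)ccc1C(CC)(CC)c1ccc(OCS(=O)(=O)c2ccccc2)c(C)c1`) gives 17900 nM. Compound 2 (`CCn1c(C(=O)NCCC(=O)OC)ccc1C(CC)(CC)c1ccc(OCS(=O)(=O)c2ccccc2)c(C)c1`) gives > 50000 nM, which is a limit of the assay and not a number. Compound 3 (`CCn1c(C(=O)N[C@@H](CC(=O)OC)C(=O)OC)ccc1C(CC)(CC)c1ccc(OCS(=O)(=O)c2ccccc2)c(C)c1`) gives > 50000 nM, which is likewise a limit. Compound 2 thus stands at the limit of > 50000 nM in this assay, at which 2 of the 3 values shown sit.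

Compound 4 (`CCn1c(C(=O)N[C@@H](C)CO)ccc1C(CC)(CC)c1ccc(OCS(=O)(=O)c2ccccc2)c(C)c1`) departs from compound 2 in one place, on an amide-type nitrogen: 1-(hydroxymethyl)ethyl in place of 2-(methoxycarbonyl)ethyl on an amide-type nitrogen. Going by the values given here, two measured steps bear on this change. Moving from the 1-(methoxycarbonyl)ethyl group to the 2-(methoxycarbonyl)ethyl group gave an at least 2.7-fold higher number from compound 1 to compound 2 (0.44 log units; beyond the scatter). Adding a further methoxycarbonyl gave an at least 2.7-fold higher number from compound 1 to compound 3 (0.44 log units; beyond the scatter). Going by these compounds, both steps end at a limit, so their full sizes remain unknown.

The 1-(hydroxymethyl)ethyl group of compound 4 is attached through the same 1-position of the ethyl chain as the group in compound 1, which gives 17900 nM. Compound 3 shares that attachment too and goes against any simple reading, so the expectation is held loosely. A modest move to a lower number is expected in this assay, and the estimated step is an at least 2.2-fold lower number from compound 2 to compound 4 (0.35 log units; beyond the scatter). The estimate for compound 4 is 22000 nM, with an expected range from 8000 nM to 60000 nM.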

Compound 4, half-maximal inhibitory concentration: 15300 nM
Compound 4: middle estimate off by 1.4-fold (0.16 log units), on the high side; measured number inside the range.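

In this assay, the change from methoxycarbonyl to hydroxymethyl on the saturated chain carbon bound to the amide-type nitrogen leaves the reading within the scatter, at a 1.2-fold lower number from compound 1 to compound 4 (0.07 log units; within the scatter), so at this position the ester is not required for a measurable value. The 1-(hydroxymethyl)ethyl group also reads clearly better than the two other ester-bearing groups, with an at least 3.2-fold lower number from compound 2 to compound 4 (0.51 log units; beyond the scatter) and an at least 3.2-fold lower number from compound 3 to compound 4 (0.51 log units; beyond the scatter), which gives compound 1 and compound 4 a shared attachment through the 1-position of the ethyl chain, although compound 3 has that attachment too and goes against any rule based on attachment alone. Compound 2 stays a limit and not a number, so the full size of its step remains unknown: the limit of > 50000 nM in this assay, at which 2 of the 4 values shown sit.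

Going by these compounds, whether an amine or a carboxylic acid in place of the hydroxymethyl would keep a reading of this order, and whether a longer chain ending in a hydroxyl would do the same, remains open. Also open, on these data alone, is what the opposite arrangement at the defined stereocentre of the 1-(hydroxymethyl)ethyl group would give, and how an unbranched 2-hydroxyethyl group would compare.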